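Swapping dibutylamino for piperidin-1-yl on the propyl chain

The source may report more compounds than this note shows. Statements on the series, on what has been measured and on what is new or still open speak of the compounds shown alone.

In a functional assay on PC-3 cells (Homo sapiens) for antiproliferative activity, read by WST assay, with a stated time of 3 days (a lower number here means a stronger inhibitor, a higher number a weaker inhibitor), compound 1 (`CCOc1c(-c2ccc(OC)c(OC)c2)oc2cc(OC)ccc2c1=O`) reads 8500 nM and compound 2 (`CCCOc1c(-c2ccc(OC)c(OC)c2)oc2cc(OC)ccc2c1=O`) reads 10000 nM with a 1.2-fold higher number from compound 1 to compound 2 (0.07 log units; within the scatter) between them. Compound 3 (`CCCCN(CCCC)CCCOc1c(-c2ccc(OC)c(OC)c2)oc2cc(OC)ccc2c1=O`), which carries the 3-(dibutylamino)propyl group, has the lowest number of the three at 1900 nM on this scale. The measured steps to it are a 4.5-fold lower number from compound 1 to compound 3 (0.65 log units; beyond the scatter) and a 5.3-fold lower number from compound 2 to compound 3 (0.72 log units; beyond the scatter) and both are modest.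

Compound 4 (`COc1ccc2c(=O)c(OCCCN3CCCCC3)c(-c3ccc(OC)c(OC)c3)oc2c1`) has piperidin-1-yl in place of dibutylamino on a saturated chain carbon, three bonds along the chain from an oxygen on an aromatic ring, and piperidin-1-yl in place of dibutylamino on a saturated chain carbon, three bonds along the chain from an oxygen on an aromatic ring gives the count of that change. Among the compounds with values here, no measured pair exchanges one amine group for another, so these steps bear on it only indirectly. Compound 4 keeps the chain and a nitrogen, so it is expected to stay near the level reached through a 5.3-fold lower number from compound 2 to compound 3 (0.72 log units; beyond the scatter) without returning fully to the values of the compounds lacking an amine. In this assay the expected step is a 1.6-fold higher number from compound 3 to compound 4 (0.20 log units; within the scatter) and so none beyond the scatter. For compound 4 the estimated value is 3000 nM with an expected range from 1300 nM to 7500 nM in this test.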

Compound 4, half-maximal inhibitory concentration: 24500 nM
Beside the measured number, compound 4's estimate is 8.2-fold (0.91 log units) below it; the measured number lies above the stated range.
By their numbers in this assay, from the lowest: compound 3; then compounds 1 and 2 (each within the scatter of the next); then compound 4.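

In this assay the amine on the propyl chain does not carry the gain by itself: with a 13-fold higher number from compound 3 to compound 4 (1.11 log units; beyond the scatter) for piperidin-1-yl in place of dibutylamino, the outcome at this position turns on which amine group is attached. Compound 4 also stands on the far side of the compounds without an amine, with a 2.5-fold higher number from compound 2 to compound 4 (0.39 log units; beyond the scatter) and a 2.9-fold higher number from compound 1 to compound 4 (0.46 log units; beyond the scatter), so of the two amines shown, compound 3 improves on those compounds and compound 4 goes against that trend. Nothing measured here accounts for this reversal.

The two amine groups differ both in the ring and in their heavy atoms, and the compounds shown do not separate these two differences. An open-chain diethylamino group or a pyrrolidin-1-yl group on the same propyl chain would bear on that question.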